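Ring expansion of a cyclic amine on the shared core

The source may report more compounds than this note shows. Statements on the series, on what has been measured and on what is new or still open speak of the compounds shown alone.

The series shares one fused core, varied only at a single ring position. Compound 1 `O=C1C=C(N2CCC2)C(=O)c2c1nc1n2[C@H]2OC[C@@H](O)[C@H]2OC1` carries an azetidine there, and in a functional assay on MGC-803 cells (Homo sapiens) for inhibition, read by sulforhodamine B assay (a higher number here means a weaker inhibitor, a lower number a stronger inhibitor), compound 1 reports only a limit, > 16000 nM. The two arylamino analogues are different: compound 2 `COc1ccc(NC2=CC(=O)c3c(nc4n3[C@H]3OC[C@@H](O)[C@H]3OC4)C2=O)cc1` gives 2150 nM in this assay, and compound 3 `O=C1C(Nc2cccc(F)c2)=CC(=O)c2c1nc1n2[C@H]2OC[C@@H](O)[C@H]2OC1` gives 1470 nM; the change between them, a 1.5-fold lower number from compound 2 to compound 3 (0.17 log units; within the scatter), stays inside the scatter. Compound 4 `O=C1C=C(N2CCCC2)C(=O)c2c1nc1n2[C@H]2OC[C@@H](O)[C@H]2OC1` differs from compound 1 as follows: pyrrolidin-1-yl in place of azetidin-1-yl on a double-bonded ring carbon. Within the data shown here, no measured step exchanges one saturated cyclic amine for another, so the step from compound 1 to compound 4 has no direct precedent; the only evidence for this part of the core is that compound 1 sits at the limit (the limit of > 16000 nM in this assay, at which 1 of the 3 values shown sits), while compounds 2 and 3 differ from it in more than ring size. Compound 4 is therefore expected to remain weak, with an estimated value of 15000 nM (range 4000 nM to 60000 nM). The expected step of an at least 1.0-fold lower number from compound 1 to compound 4 (0.02 log units; that floor lies within the scatter) is thus small and uncertain, with a fair chance that only a limit is reported again.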

Compound 4, half-maximal inhibitory concentration: > 16000 nM
Compound 4 was reported as a limit; the forecaster's own chance of this, stated with the estimate: 55%; at least 1.0-fold (0.02 log units) between middle value and limit.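

Compound 1 and compound 4 both stand at a limit in this assay, so the step between them cannot be read: the limit of > 16000 nM in this assay, at which 2 of the 4 values shown sit.

The compounds shown leave open how far past that limit either compound lies, and so whether pyrrolidin-1-yl differs at all from azetidin-1-yl in this assay.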